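Aryl ether imidazolines: five-membered heteroaryl swap on the core

This account rests on a few compounds, and the source may have more. Where it says the series, first, only, none or still open, it means among the compounds named here.

Measured compounds in a functional assay for activation of Alpha-1B adrenergic receptor (Homo sapiens), read by calcium flux; a lower number here means that less compound is needed, a higher number that more compound is needed for the effect:
compound 1, `c1ccc(-c2ccsc2)c(OCC2=NCCN2)c1`, 15.9 nM
compound 2, `c1ccc(-c2nccs2)c(OCC2=NCCN2)c1`, 20 nM
compound 3, `Cc1cnsc1-c1ccccc1OCC1=NCCN1`, only a limit, < 100000 nM

Compounds 1 and 2 sit close together, and the step of a 1.3-fold higher number from compound 1 to compound 2 (0.10 log units; within the scatter) is within the scatter. In this assay compound 3 is known only as a limit, < 100000 nM. For that reason the steps a step that the limit leaves unreadable from compound 1 to compound 3 and a step that the limit leaves unreadable from compound 2 to compound 3 cannot be sized, and the limit line the limit of < 100000 nM in this assay, at which 1 of the 3 values shown sits, is all that is known of compound 3.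

Compound 4 is `Cn1nccc1-c1ccccc1OCC1=NCCN1`. It differs from compound 3 in one place: 1-methyl-1H-pyrazol-5-yl in place of 4-methyl-1,2-thiazol-5-yl on an aromatic carbon. Going by the values given here, none of the measured steps shows this exchange, so the sizing has to rest on the whole set: two compounds near each other in this assay and one compound known only as a limit. With the heteroaryl on the shared core exchanged again, the value of compound 4 is expected to fall between the two readable values and the limit, with a wide range; compound 4 is estimated at 500 nM, range 20 nM to 20000 nM. The step expected in this assay is a step that the limit leaves unreadable from compound 3 to compound 4, its direction not readable from a limit.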

Compound 4, half-maximal effective concentration: < 100000 nM
Compound 4: only a limit was reported; the forecaster's own chance of this, stated with the estimate: 25%; the middle value is on the limit's open side.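

In this assay compound 4 is known only as a limit, < 100000 nM, and its steps to compound 1, compound 2 and compound 3 cannot be read. Still open, going by these compounds, is whether 1-methyl-1H-pyrazol-5-yl and 4-methyl-1,2-thiazol-5-yl differ at all on the shared core in this assay.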